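Adding one methoxy to compound 3

This account rests on a few compounds, and the source may have more. Where it says the series, first, only, none or still open, it means among the compounds named here.

In a functional assay on MCF7 cells (Homo sapiens) for antiproliferative activity, read by sulforhodamine B assay, with a stated time of 48 h (a higher number here means a weaker inhibitor, a lower number a stronger inhibitor), three related compounds have been measured so far. Compound 1 (`COc1ccc(C=C(C(=O)/C=C/c2cccc(OC)c2OC)C(=O)/C=C/c2cccc(OC)c2OC)cc1OC`) gives 560 nM here, compound 2 (`COc1cccc(/C=C/C(=O)C(=Cc2cc(OC)c(OC)c(OC)c2)C(=O)/C=C/c2cccc(OC)c2OC)c1OC`) gives 840 nM here, and compound 3 (`COc1cccc(C=C(C(=O)/C=C/c2cccc(OC)c2OC)C(=O)/C=C/c2cccc(OC)c2OC)c1OC`) gives 520 nM here. Compound 3 cannot be told apart from the other two, as the steps show: a 1.1-fold lower number from compound 1 to compound 3 (0.03 log units; within the scatter) and a 1.6-fold lower number from compound 2 to compound 3 (0.21 log units; within the scatter) are both small.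

Compound 4 (`COc1cccc(/C=C/C(=O)C(=Cc2ccc(OC)c(OC)c2OC)C(=O)/C=C/c2cccc(OC)c2OC)c1OC`) differs from compound 3 in one place: methoxy in place of hydrogen on an aromatic carbon in all. This is methoxy in place of hydrogen on an aromatic carbon, which turns a 2,3-dimethoxyphenyl into a 2,3,4-trimethoxyphenyl.

The closest guide is the same kind of swap elsewhere in the series, which gave a 1.5-fold higher number from compound 1 to compound 2 (0.18 log units; within the scatter) and so made no clear difference. It sits at a different place, so it guides only loosely. No step beyond the scatter is therefore expected in this assay for this change, perhaps a slight drift towards a higher number. Compound 4 is estimated at 600 nM with 280 nM to 1300 nM as its likely range.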

Compound 4, half-maximal inhibitory concentration: 380 nM
Compound 4: middle estimate off by 1.6-fold (0.20 log units), on the high side; measured number inside the range.
By their numbers in this assay, from the lowest: compounds 4, 3, 1 and 2 (each within the scatter of the next, the first and the last beyond it).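

In this assay the methoxy that turns a 2,3-dimethoxyphenyl into a 2,3,4-trimethoxyphenyl is tolerated: the step is a 1.4-fold lower number from compound 3 to compound 4 (0.14 log units; within the scatter) and the comparison with the 3,4-dimethoxyphenyl compound is a 1.5-fold lower number from compound 1 to compound 4 (0.17 log units; within the scatter) as well. The arrangement of the methoxy groups now shows its first step beyond the scatter, as moving from the 3,4,5-trimethoxyphenyl to the 2,3,4-trimethoxyphenyl gives a 2.2-fold lower number from compound 2 to compound 4 (0.34 log units; beyond the scatter) and so a modest gain. The added methoxy also shows no dependence on its place that stands clear of the scatter: the same change on two cores in this assay, a 1.5-fold higher number (0.18 log units; within the scatter) from compound 1 to compound 2 and a 1.4-fold lower number (0.14 log units; within the scatter) from compound 3 to compound 4, 2.1-fold (0.31 log units) apart, within the scatter of two such steps.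

All the aromatic substituents shown are methoxy groups, so it stays open whether a hydroxy group or an amine para to a large group would hold the number at this level.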